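The compounds below may be only part of what the source reports. "The series", "measured", "known", "first", "only" and "open" are said of these compounds alone.

Working notes on the series. The shared core of compound 1 `Cc1ccc(-c2n[nH]cc2N2CCCNCC2)cc1` carries a methyl on the aromatic ring; in an assay on isolated protein for binding affinity to 5-hydroxytryptamine receptor 3A (Homo sapiens) (a higher number here means a weaker inhibitor, a lower number a stronger inhibitor), compound 1 gives 744 nM. Compound 2 `Fc1ccc(-c2n[nH]cc2N2CCCNCC2)cc1` carries a fluoro in its place, and in this assay compound 2 gives 1810 nM. Among the compounds with values here, the one measured step, a 2.4-fold higher number from compound 1 to compound 2 (0.39 log units; beyond the scatter), is the only guide to what a change on that aromatic carbon does here. Compound 3 `COc1ccc(-c2n[nH]cc2N2CCNCC2)cc1` has a smaller saturated ring on the core and a methoxy on the aromatic carbon. In this assay compound 3 gives > 10000 nM, which is a limit of the assay and not a number; this is the case described by the limit of > 10000 nM in this assay, at which 1 of the 3 values shown sits. Where compound 3 stands is therefore only bounded from one side. Compound 4 `Clc1ccc(-c2n[nH]cc2N2CCNCC2)cc1` differs from compound 3 by chloro in place of methoxy on an aromatic carbon. The step from compound 1 to compound 2 was modest, and it concerns a different pair of groups, so it bears on this change only loosely. In this assay compound 4 is expected to give a number rather than a limit, around 5000 nM, within 1500 nM to 20000 nM; the step that this implies, an at least 2.0-fold lower number from compound 3 to compound 4 (0.30 log units; that floor lies within the scatter), is an estimate and may still end at the limit.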

Compound 4, inhibition constant: 1790 nM
Estimate against measurement, compound 4: 2.8-fold (0.45 log units) above; the measured number falls inside the stated range.
By their numbers in this assay, from the lowest: compound 1; then compounds 4 and 2 (each within the scatter of the next). At a limit, above all of these: compound 3.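

In this assay, chloro in place of methoxy on an aromatic carbon, para to a large group, gives an at least 5.5-fold lower number from compound 3 to compound 4 (0.74 log units; beyond the scatter), so on the core with the smaller saturated ring this position responds to the group it carries. Within the data shown here, the earlier step concerned only methyl and fluoro on the core of compound 1, so this is the first reading for methoxy and chloro at this position. The size of the new step is only a floor, and the value of compound 3 is a limit of the assay, not a number: the limit of > 10000 nM in this assay, at which 1 of the 4 values shown sits.

The compounds shown do not reveal how the size of the saturated ring acts with the same aromatic group held fixed. Going by these compounds, it also remains open how this aromatic carbon responds to an amine, a nitrile or a carboxylic acid.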